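The source may report more compounds than this note shows. Statements on the series, on what has been measured and on what is new or still open speak of the compounds shown alone.

Measured so far: compound 1 `CCCCCCCCCCCCCCNC(=O)[C@H](CO)/N=C/c1cccc([N+](=O)[O-])c1` with 104000 nM and compound 2 `CCCCCCCCCCCCCCNC(=O)[C@H](CO)NCc1ccccc1Cl` with 43700 nM, both in a functional assay on cells (Homo sapiens) for cytotoxicity, read by MTT assay, with a stated time of 24 h; a lower number here means a stronger inhibitor, a higher number a weaker inhibitor.

Compound 2 stands lowest of the two numbers in this assay; compound 1 sits a step higher, beyond the usual scatter. Compound 3 `CCCCCCCCCCCCCCNC(=O)[C@H](CO)/N=C/c1cccc(C)c1` differs from compound 2 by a group of 9 heavy atoms (8 carbon, 1 nitrogen; one six-membered aromatic ring of carbon only) in place of a group of 9 heavy atoms (7 carbon, 1 nitrogen, 1 chlorine; one six-membered aromatic ring of carbon only), on a saturated chain carbon bound to a carbonyl carbon and a saturated chain carbon. Among the compounds with values here, no step between measured compounds is known for this change. Compound 3 is expected to move toward a higher number, with a 1.8-fold higher number from compound 2 to compound 3 (0.26 log units; within the scatter) a modest step at most, partly because compound 1, which shares the double bond outside the ring, gives 104000 nM. Compound 3 is estimated at 80000 nM, within 35000 nM to 180000 nM.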

Compound 3, half-maximal inhibitory concentration: 82900 nM
For compound 3 the middle estimate is 1.0-fold (0.02 log units) below the measured one; the measured number falls inside the stated range.
By their numbers in this assay, from the lowest: compounds 2, 3 and 1 (each within the scatter of the next, the first and the last beyond it).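

In this assay, within the data shown here, methyl in place of nitro on an aromatic carbon gives a 1.3-fold lower number from compound 1 to compound 3 (0.10 log units; within the scatter) and is the first change read on the ring itself. Replacing the (2-chlorobenzyl)amino group with the group carrying the double bond outside the aromatic ring, on the saturated chain carbon, gives a 1.9-fold higher number from compound 2 to compound 3 (0.28 log units; within the scatter) and so also stays inside the scatter. No evidence is available that would explain these numbers. The compounds shown leave open what an amine or a carboxylic acid on the aromatic ring would give. They also leave open what a shorter chain in place of the long chain would give.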